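The source may report more compounds than this note shows. Statements on the series, on what has been measured and on what is new or still open speak of the compounds shown alone.

Values in an ADME assay on L6 cells (Rattus norvegicus) for cytotoxicity; on this read-out lower numbers stand for stronger inhibition and higher numbers for weaker inhibition:
compound 1 `COc1ccc(N2CCN(C(=O)Cn3cnc([N+](=O)[O-])n3)CC2)cc1`: 133000 nM
compound 2 `Cc1ccc(N2CCN(C(=O)Cn3cnc([N+](=O)[O-])n3)CC2)cc1`: 148000 nM
compound 3 `O=C(Cn1cnc([N+](=O)[O-])n1)N1CCN(c2ccc(Cl)cc2)CC1`: > 285000 nM

The entry for compound 3 is a limit of the assay and not a number. Among the measured compounds shown here, it is the only one of the three values that is a limit: the limit of > 285000 nM in this assay, at which 1 of the 3 values shown sits.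

Compound 4 `O=C(Cn1cnc([N+](=O)[O-])n1)N1CCN(c2ccccn2)CC1` carries pyridin-2-yl in place of 4-chlorophenyl on an amine nitrogen in a ring, and the counted difference from compound 3 is this: pyridin-2-yl in place of 4-chlorophenyl on an amine nitrogen in a ring.

The measured steps bear on this change only indirectly, as each exchanges a group on an aromatic carbon and none exchanges the aromatic ring itself. The first is a 1.1-fold higher number from compound 1 to compound 2 (0.05 log units; within the scatter). The second is an at least 2.1-fold higher number from compound 1 to compound 3 (0.33 log units; beyond the scatter). The third is an at least 1.9-fold higher number from compound 2 to compound 3 (0.28 log units; that floor lies within the scatter), and its floor does not clear the scatter.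

For the measured compounds named here, only the step of an at least 2.1-fold higher number from compound 1 to compound 3 (0.33 log units; beyond the scatter) is beyond the scatter, and it is at least modest. On that evidence, a step of similar modest size is expected in this assay, towards a lower number, and it may not clear the scatter.

For compound 4 the expected value is 220000 nM, with an estimated range from 120000 nM to 330000 nM. The estimate corresponds to an expected at least 1.2-fold lower number from compound 3 to compound 4 (0.11 log units; that floor lies within the scatter).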

Compound 4, half-maximal inhibitory concentration: 173000 nM
For compound 4 the middle estimate is 1.3-fold (0.10 log units) above the measured one; the measured number falls inside the stated range.
By their numbers in this assay, from the lowest: compounds 1, 2 and 4 (each within the scatter of the next). At a limit, above all of these: compound 3.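

In this assay, among the compounds shown here, the exchange of the aromatic ring itself on the amine nitrogen in the ring, which no earlier step covered, gives a 1.2-fold higher number from compound 2 to compound 4 (0.07 log units; within the scatter) and a 1.3-fold higher number from compound 1 to compound 4 (0.11 log units; within the scatter), so pyridin-2-yl, with its ring nitrogen and one hydrogen-bond acceptor, reads level with both 4-methylphenyl and 4-methoxyphenyl at this position. Against 4-chlorophenyl the reading is an at least 1.6-fold lower number from compound 3 to compound 4 (0.21 log units; that floor lies within the scatter), and that floor does not clear the scatter, so this change is not shown to lower the number, and its true size stays unfixed. Compound 3 remains the only entry at a limit of the assay, so its step gives a floor and not a size: the limit of > 285000 nM in this assay, at which 1 of the 4 values shown sits.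

The compounds shown leave open whether a non-aromatic group on the same nitrogen, such as cyclohexyl or benzyl with its added carbon, or another aromatic ring with more nitrogen, such as pyrimidin-2-yl, would stay level with compound 4. Also open, on these data alone, is whether a chloro group on the pyridine ring of compound 4 would bring its number to the limit seen for compound 3.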